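The source may hold more compounds than are shown below. What is called first, only, known or untested is meant among the compounds shown, and "the series" means these compounds.

Measured compounds and values:
- compound 1, `Cc1cc(-c2ccnc(C(F)F)c2)ncc1OC[C@@](C)(N)CC(C)C`, 0.3 nM
- compound 2, `COC(=O)Nc1cc(-c2cnc(OC[C@@](C)(N)CC(C)C)c(OC)c2)ccn1`, 2.5 nM
- compound 3, `COC(=O)Nc1cc(-c2ccc(OC[C@@](C)(N)CC(C)C)cn2)ccn1`, 18 nM

In an assay on brain (strain C57BL6) for displacement of a labelled ligand from AP2-associated protein kinase 1 (Mus musculus), read by scintillation counting, with a stated time of 1 h (on this read-out lower numbers stand for stronger inhibition and higher numbers for weaker inhibition), compound 2 sits second highest of the three numbers shown. Its nearest neighbour is compound 3, whose number is higher by a margin beyond the scatter; its furthest is compound 1, whose number is lower, again beyond the scatter. Among the measured compounds shown here, no pair of the measured compounds differs in a single place, so no step between them is drawn here.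

The unmeasured compound 4, `COC(=O)Nc1cc(-c2cnc(OC[C@@](C)(N)CC(C)C)c(Cl)c2)ccn1`, is reached from compound 2 by one change: chloro in place of methoxy on an aromatic carbon. The change sits ortho to a (2-amino-2,4-dimethylpentyl)oxy group, two atoms from the ring nitrogen, meta to a large group. For the measured compounds named here, nothing among the measured compounds isolates the effect of a substituent at this position, so there is no basis for expecting a step beyond the scatter in either direction in this assay.

Compound 4 is therefore estimated at 2.5 nM, with a range of 0.8 nM to 8 nM, which means an expected step of no change at the digits printed from compound 2 to compound 4 (within the scatter) within the scatter.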

Compound 4, inhibition constant: 0.11 nM
Estimate against measurement, compound 4: 23-fold (1.36 log units) above, and the stated range ends above it.
By their numbers in this assay, from the lowest: compound 4; then compound 1; then compound 2; then compound 3.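

Chloro in place of methoxy on this aromatic carbon in this assay gives a 23-fold lower number from compound 2 to compound 4 (1.36 log units; beyond the scatter) and so marks this position, ortho to a (2-amino-2,4-dimethylpentyl)oxy group and two atoms from the ring nitrogen, as one where a single substituent change moves the number well beyond the scatter. Among the compounds shown here, the earlier compounds held no pair isolating a substituent here, so this is the first direct reading of the position. The step comes with one heavy atom entering where two leave and with one hydrogen-bond acceptor fewer by count, but no measurement shown accounts for its size.

Going by these compounds, whether the step belongs to chloro itself or to the loss of methoxy stays open; hydrogen, methyl or bromo at this position would separate the two. Also open, on these data alone, is whether the same change carries over to a core without the methyl carbamate.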